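The source may report more compounds than this note shows. Statements on the series, on what has been measured and on what is new or still open speak of the compounds shown alone.

Going by the values given here, compound 2 `Cc1cccc(C(=O)Nc2cccc(-c3oc4cc(-c5ccc(F)cc5)ccc4c(=O)c3O)c2)c1` stands at the lower of the two numbers so far: in a functional assay on HeLa cells (Homo sapiens) for antiproliferative activity, read by CCK-8 assay, with a stated time of 72 h (a higher number here means a weaker inhibitor, a lower number a stronger inhibitor), compound 2 gives 6650 nM, while compound 1 `O=C(Nc1cccc(-c2oc3cc(-c4ccc(F)cc4)ccc3c(=O)c2O)c1)c1ccc(C(F)(F)F)cc1` gives 17400 nM. Among the compounds with values here, the only step between measured compounds is a 2.6-fold lower number from compound 1 to compound 2 (0.42 log units; beyond the scatter), a change on the carbonyl carbon of the amide. Compound 3 `O=C(Nc1cccc(-c2oc3cc(-c4ccc(F)cc4)ccc3c(=O)c2O)c1)c1ccc(Cl)nc1` differs from compound 2 at that same carbonyl carbon: 6-chloropyridin-3-yl in place of 3-methylphenyl on a carbonyl carbon. Within the data shown here, the one measured step bears on this change only indirectly, since it shows that replacing one aromatic group on this carbonyl carbon by another can move the number by a modest amount, with the 3-methylphenyl giving the lower number of the two. Among the measured compounds shown here, compound 3 gives up that 3-methylphenyl for a ring that is neither of the two measured ones, so there is no step that speaks directly to the 6-chloropyridin-3-yl. On that footing, the number for compound 3 is expected to move by a 1.5-fold higher number from compound 2 to compound 3 (0.18 log units; within the scatter), a modest rise that may or may not clear the scatter. Compound 3 is therefore estimated at 10000 nM, within a range from 4000 nM to 25000 nM.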

Compound 3, half-maximal inhibitory concentration: 4080 nM
The estimate for compound 3 lay 2.5-fold (0.39 log units) above the measured number; low and high end bracket the measured number.
By their numbers in this assay, from the lowest: compounds 3 and 2 (each within the scatter of the next); then compound 1.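

In this assay, the carbonyl carbon of the amide now carries a ring with a nitrogen and a chlorine in it, and the result is a 1.6-fold lower number from compound 2 to compound 3 (0.21 log units; within the scatter), so the 6-chloropyridin-3-yl and the 3-methylphenyl cannot be told apart on these numbers. Measured against the 4-(trifluoromethyl)phenyl, the same new ring gives a 4.3-fold lower number from compound 1 to compound 3 (0.63 log units; beyond the scatter), so among the three compounds shown, compound 1 alone stands clear of the other two, and two rings of quite different make-up now sit together within the scatter. No measurement shown gives a reason for these steps.

The ring nitrogen and the chlorine enter together in compound 3, so the compounds shown do not tell what each contributes alone, and a plain pyridin-3-yl or a 4-chlorophenyl on this carbonyl carbon would be needed to separate them. Going by these compounds, it also remains open how the number would respond to a group that is not an aromatic ring at this place, such as a morpholine, a cyclohexyl or a longer alkyl chain, or to a ring bearing an amine or a carboxylic acid.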